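This account rests on a few compounds, and the source may have more. Where it says the series, first, only, none or still open, it means among the compounds named here.

In an ADME assay on PC-3 cells (Homo sapiens) for cytotoxicity, read by WST assay, tested at 100 uM (a lower number here means less inhibition, a higher number more inhibition at the concentration tested (going by the name of the read-out)), compound 1 `C=Cc1cccc(C(=O)N2CCCC(C(=O)Nc3ccc(Cl)cc3)C2)c1` gives 0%. Compound 2 `O=C(Nc1cccc([N+](=O)[O-])c1)C1CCCN(C(=O)c2cc(C(F)(F)F)cc(C(F)(F)F)c2)C1` gives 9% in this assay, and compound 3 `O=C(Nc1cccc(-c2cnco2)c1)C1CCCN(C(=O)c2cc(C(F)(F)F)cc(C(F)(F)F)c2)C1` gives 9%, each of them a number that lies within the scatter of the value of compound 1, so the three measured compounds cannot be told apart on what this assay shows. Among the compounds with values here, the only step between measured compounds that differ in one place is no change at the digits printed from compound 2 to compound 3 (within the scatter), and it concerns the amide-linked aromatic ring, which compound 1 and compound 4 share unchanged.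

Compound 4 `CS(=O)(=O)Nc1cccc(C(=O)N2CCCC(C(=O)Nc3ccc(Cl)cc3)C2)c1` differs from compound 1 by methanesulfonamido in place of vinyl on an aromatic carbon. Within the data shown here, no measured pair shows a methanesulfonamido entering or a vinyl leaving, so nothing among the measured steps bears directly on this change, and every step recorded in this assay has stayed within the scatter. The step of a number 4 percentage points higher from compound 1 to compound 4 (within the scatter) is therefore expected to stay within the scatter as well. Compound 4 is expected to give about 4% in this assay, within a range from 0% to 15%.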

Compound 4, a percentage reported as inhibition, at one concentration (the size of the read-out at that concentration, not a potency): 3%
Compound 4: middle estimate off by 1 percentage points, on the high side; measured number inside the range.
By their numbers in this assay, from the lowest: compounds 1, 4, 2 and 3 (each within the scatter of the next).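

In this assay, putting methanesulfonamido in place of vinyl on an aromatic carbon, meta to a large group, gives a number 3 percentage points higher from compound 1 to compound 4 (within the scatter). Within the data shown here, this is the first measured step at this position, and it shows that the read-out does not separate the two compounds, even though the entering group is larger and carries a hydrogen-bond donor and hydrogen-bond acceptors that vinyl lacks. No evidence is available that would explain this result.

The compounds shown leave open whether an amine, a carboxylic acid or a longer chain at this position would also stay within the scatter of compound 1. They also leave open whether methanesulfonamido would give the same reading on the core of compound 2, which carries trifluoromethyl groups and a nitro group.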